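Moving the naphthalene attachment point on a chloro analogue

The source may hold more compounds than are shown below. What is called first, only, known or untested is meant among the compounds shown, and "the series" means these compounds.

Three compounds have been measured in a functional assay on HepG2 cells (Homo sapiens) for inhibition, read by CCK-8 assay, with a stated time of 48 h; a higher number here means a weaker inhibitor, a lower number a stronger inhibitor:
compound 1 `Cc1ccc(C2=NN(C3=NC(c4ccccc4)CS3)C(c3ccc4ccccc4c3)C2)cc1` gives 14700 nM
compound 2 `Cc1ccc(C2=NN(C3=NC(c4ccccc4)CS3)C(c3cccc4ccccc34)C2)cc1` gives 10400 nM
compound 3 `Clc1ccc(C2=NN(C3=NC(c4ccccc4)CS3)C(c3cccc4ccccc34)C2)cc1` gives 18700 nM

Compound 1 and compound 2 share a core and differ only in how the naphthalene is attached: naphthalen-2-yl in place of naphthalen-1-yl on a saturated ring carbon. The resulting step, a 1.4-fold higher number from compound 2 to compound 1 (0.15 log units; within the scatter), lies within the usual scatter, so the two values cannot be ranked. Compound 3 differs from compound 2 in one spot on the outer ring: chloro in place of methyl on an aromatic carbon. Here too the step, a 1.8-fold higher number from compound 2 to compound 3 (0.25 log units; within the scatter), is within the scatter. For the measured compounds named here, compound 3 carries the highest of the three numbers, but its gaps to compound 1 and to compound 2 are both within the scatter, so no compound can be called weaker or stronger than another.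

Compound 4 `Clc1ccc(C2=NN(C3=NC(c4ccccc4)CS3)C(c3ccc4ccccc4c3)C2)cc1` has not yet been measured. It relates to compound 3 as compound 1 relates to compound 2: naphthalen-2-yl in place of naphthalen-1-yl on a saturated ring carbon. The surroundings are not identical, since the ring atom two ring bonds away bears a 4-chlorophenyl group in compound 3 but a 4-methylphenyl group in compound 2, so this is the same kind of change rather than the same change.

For compound 3 to compound 4 in this assay the step is expected to be about a 1.3-fold higher number from compound 3 to compound 4 (0.13 log units; within the scatter), because the same kind of change gave a 1.4-fold higher number from compound 2 to compound 1 (0.15 log units; within the scatter). Compound 4 is therefore estimated at 25000 nM, most likely between 12000 nM and 52000 nM.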

Compound 4, half-maximal inhibitory concentration: 22100 nM
Compound 4: middle estimate off by 1.1-fold (0.05 log units), on the high side; the measured number falls inside the stated range.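

In this assay, naphthalen-2-yl in place of naphthalen-1-yl gives a 1.2-fold higher number from compound 3 to compound 4 (0.07 log units; within the scatter), and chloro in place of methyl gives a 1.5-fold higher number from compound 1 to compound 4 (0.18 log units; within the scatter), so neither change can be said to alter the number on this second core. Carrying the naphthalene change from one core to the other gives no sign of a different outcome, but steps this small cannot show that a real effect transfers between cores, only that nothing measurable separates them: the same change on two cores in this assay, a 1.4-fold higher number (0.15 log units; within the scatter) from compound 2 to compound 1 and a 1.2-fold higher number (0.07 log units; within the scatter) from compound 3 to compound 4, 1.2-fold (0.08 log units) apart, within the scatter of two such steps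

The same caution applies to chloro in place of methyl, where the two steps also agree without either one being large enough to read as a true effect: the same change on two cores in this assay, a 1.8-fold higher number (0.25 log units; within the scatter) from compound 2 to compound 3 and a 1.5-fold higher number (0.18 log units; within the scatter) from compound 1 to compound 4, 1.2-fold (0.08 log units) apart, within the scatter of two such steps

The compounds shown leave open whether any change at these two places can move the number beyond the usual scatter, since every step here stays within it. An amine or a carboxylic acid in place of the chloro, or a longer chain in place of the naphthalene, would test the series with a far larger change than the swaps seen so far.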